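Sugar Stereocentre Flipped on a Glycosylated Indirubin

The compounds below may be only part of what the source reports. "The series", "measured", "known", "first", "only" and "open" are said of these compounds alone.

Compound 1 `O=C1/C(=C2/C(=O)N([C@@H]3O[C@H](CO)[C@@H](O)[C@H](O)[C@H]3O)c3ccccc32)Nc2ccccc21` is an indirubin carrying a sugar on one of its nitrogens. In a functional assay on 5637 cells (Homo sapiens) for antiproliferative activity, read by crystal violet staining, with a stated time of 96 h (a higher number here means a weaker inhibitor, a lower number a stronger inhibitor), compound 1 gives 14400 nM. Compound 3 `C[C@@H]1O[C@H](N2C(=O)/C(=C3\Nc4ccccc4\C3=N/O)c3ccccc32)[C@H](O)[C@H](O)[C@H]1O`, which carries a different sugar and an oxime, gives 15500 nM in this assay, a number within the scatter of compound 1. Compound 2 `C[C@@H]1O[C@@H](N2C(=O)/C(=C3\Nc4ccccc4C3=O)c3ccccc32)[C@H](O)[C@H](O)[C@H]1O` reaches only the limit of this assay, > 25000 nM. Among the measured compounds shown here, that limit of > 25000 nM in this assay, at which 1 of the 3 values shown sits, is the one value here that is not a number.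

Compound 4 `O=C1/C(=C2/C(=O)N([C@@H]3O[C@H](CO)[C@@H](O)[C@H](O)[C@@H]3O)c3ccccc32)Nc2ccccc21` is to be measured next. It differs from compound 1 only in configuration: the two compounds have the same atoms and bonds and differ only in configuration as drawn: 1 of 6 stereo elements differ; a stereocentre at a saturated ring carbon is drawn R in compound 1 and S in compound 4. For the measured compounds named here, no measured pair shows what such a flip does, so compound 4 is expected to sit close to compound 1, with a step of a 1.0-fold higher number from compound 1 to compound 4 (0.02 log units; within the scatter) that stays within the scatter. Compound 4 is estimated at 15000 nM, between 7000 nM and 32000 nM.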

Compound 4, half-maximal inhibitory concentration: 10600 nM
Compound 4: middle estimate off by 1.4-fold (0.15 log units), on the high side; the range from low to high includes it.
By their numbers in this assay, from the lowest: compounds 4, 1 and 3 (each within the scatter of the next). At a limit, above all of these: compound 2.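

Among the compounds shown here, this is the first measured pair that isolates a single stereocentre, so nothing else can account for the step: the fact that compounds 1 and 4 differ only in the configuration as drawn. In this assay, drawing this saturated ring carbon S rather than R gives a 1.4-fold lower number from compound 1 to compound 4 (0.13 log units; within the scatter). For this one stereocentre, then, the flip produces no difference that can be told from the scatter, in a range of values where activity is already modest.

On these data alone, whether flipping any of the other stereocentres would behave the same way stays open. So does the effect of an amine or a carboxylic acid on the sugar.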